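The source may hold more compounds than are shown below. What is called first, only, known or untested is meant among the compounds shown, and "the series" means these compounds.

Four close relatives of one shared core are compared in a functional assay on HT-29 cells (Homo sapiens) for cytotoxicity, read by MTT assay, with a stated time of 72 h; on this read-out lower numbers stand for higher toxicity in this test and higher numbers for lower toxicity in this test. Compound 1 has the structure `Sc1nc(NCc2ccccc2)c2ccccc2n1`. In this assay compound 1 does not reach a number but only the limit of the test, at > 100000 nM. Compound 2, with the structure `CSc1nc(NCc2ccccc2)c2ccccc2n1`, differs from compound 1 at a single sulfur. In this assay compound 2 likewise stops at the limit, giving > 100000 nM. Compound 3, with the structure `COc1ccc(CNc2nc(SC)nc3ccccc23)cc1`, carries one further group on its outer ring. In this assay compound 3 also reaches only the limit, at > 100000 nM.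

The change from compound 2 to compound 1 is hydrogen in place of methyl on a sulfur, and its step in this assay reads a step that the two limits leave unreadable from compound 2 to compound 1. The two cores of compound 2 and compound 3 differ by methoxy in place of hydrogen on an aromatic carbon, and that step reads a step that the two limits leave unreadable from compound 2 to compound 3. Neither step can be sized because of the limit of > 100000 nM in this assay, at which 3 of the 3 values shown sit.

Compound 4, with the structure `COc1ccc(CNc2nc(S)nc3ccccc23)cc1`, is not yet measured. Within the data shown here, it differs from compound 3 by hydrogen in place of methyl on a sulfur, which is the same change, at the same place, as the one from compound 2 to compound 1. Since that earlier change left compound 1 at the limit, and compound 3 already sits at the limit, the expected step from compound 3 to compound 4 in this assay is a step that the limit leaves unreadable from compound 3 to compound 4, most likely again unreadable. Compound 4 is therefore expected to give about 150000 nM, within a band from 50000 nM to 400000 nM.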

Compound 4, concentration lethal to 50% of the cells: 63900 nM
For compound 4 the middle estimate is 2.3-fold (0.37 log units) above the measured one, within the range that was stated.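

In this assay, hydrogen in place of methyl on a sulfur gives, on the core that carries methoxy, an at least 1.5-fold lower number from compound 3 to compound 4 (0.19 log units; that floor lies within the scatter), and methoxy in place of hydrogen on an aromatic carbon, with hydrogen already on the sulfur, gives an at least 1.5-fold lower number from compound 1 to compound 4 (0.19 log units; that floor lies within the scatter). Among these compounds, each of these steps is only a floor, and that floor does not clear the usual scatter of the test, so neither one on its own proves a real difference; what the result does show is that compound 4 is the one compound of the four that gives a number rather than a limit. It does not show whether the change on sulfur carries over from one core to the other, because the same change from compound 2 to compound 1 cannot be read, and neither can the other steps among the first three compounds: the limit of > 100000 nM in this assay, at which 3 of the 4 values shown sit.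

Methoxy is the only group shown on the outer ring, so it remains open how an amine or a carboxylic acid at that place would read in this assay. On the sulfur only hydrogen and methyl appear, which leaves a longer chain such as ethyl open as well.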